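The compounds below may be only part of what the source reports. "The series", "measured", "known", "first", "only" and "open" are said of these compounds alone.

Of the compounds shown here, three sharing one core have been tested in a functional assay on SK-OV-3 cells (Homo sapiens) for inhibition, read by sulforhodamine B assay, with a stated time of 48 h; a higher number here means that more compound is tolerated, a lower number that less compound is tolerated. Compound 1 `Nc1cc(N)c2nc(-c3ccccc3)c(Oc3ccc(Cl)c(Cl)c3)nc2c1` reaches only the limit of the assay, < 100000 nM. Compound 2 `CCOC(=O)[C@H](CCC(=O)O)NC(=O)c1ccc(CNc2nc3cc(N)cc(N)c3nc2-c2ccccc2)cc1` likewise shows only a limit, < 100000 nM. Among the compounds with values here, compound 3 `Nc1cc(N)c2nc(-c3ccccc3)c(NCc3ccc(Cl)c(Cl)c3)nc2c1` gives 69200 nM, the one measured number in the set. The other two values sit at the limit of < 100000 nM in this assay, at which 2 of the 3 values shown sit. Compound 4 `COc1ccc(CNc2nc3cc(N)cc(N)c3nc2-c2ccccc2)cc1OC` is the next one to be tested, and it differs from compound 3 in a single place: 3,4-dimethoxyphenyl in place of 3,4-dichlorophenyl on a saturated chain carbon bound to a nitrogen on an aromatic ring. Within the data shown here, no step between two measured compounds is available to guide the size of this change, so the expectation is a step no larger than the usual scatter, a 1.2-fold higher number from compound 3 to compound 4 (0.06 log units; within the scatter), in either direction. Compound 4 is therefore estimated at 80000 nM, within 30000 nM to 200000 nM.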

Compound 4, concentration lethal to 50% of the cells: < 100000 nM
Compound 4 gave a limit, no number (the forecaster's own chance of this, stated with the estimate: 40%); the middle value does not contradict the limit.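

Compound 4 gives the limit < 100000 nM and no number, so the step between compound 3 and compound 4 cannot be read. How far the 3,4-dimethoxyphenyl and 3,4-dichlorophenyl groups differ in this assay stays open: the limit of < 100000 nM in this assay, at which 3 of the 4 values shown sit.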